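Fluoro for chloro on the benzyl of compound 3

The compounds below may be only part of what the source reports. "The series", "measured", "known", "first", "only" and "open" are said of these compounds alone.

In an in vitro functional assay on cells for agonist activity at Bombesin receptor subtype-3 (Mus musculus), read by luminescence and calcium flux (on this read-out lower numbers stand for an effect already at smaller amounts and higher numbers for an effect only at larger amounts of compound), compound 1 `O=C(O)c1ccccc1-c1ccc(CCc2ncc(CC3CCCCC3)[nH]2)cc1` gives 7.3 nM, compound 2 `N#Cc1ccc(Cc2cnc(CCc3ccc(-c4ccccc4C(=O)O)cc3)[nH]2)cc1` gives 723 nM, and compound 3 `O=C(O)c1ccccc1-c1ccc(CCc2ncc(Cc3ccc(Cl)cc3)[nH]2)cc1` gives 102 nM, the second highest of the three numbers; the steps were a 99-fold higher number from compound 1 to compound 2 (2.00 log units; beyond the scatter), a 14-fold higher number from compound 1 to compound 3 (1.15 log units; beyond the scatter) and a 7.1-fold lower number from compound 2 to compound 3 (0.85 log units; beyond the scatter). Compound 4 `O=C(O)c1ccccc1-c1ccc(CCc2ncc(Cc3ccc(F)cc3)[nH]2)cc1` differs from compound 3 by fluoro in place of chloro on an aromatic carbon. Within the data shown here, only the step from compound 2 to compound 3 bears on a change of this group on the same carbon, and it was modest; a smaller shift is expected here, with the number for compound 4 in this assay likely somewhat higher than for compound 3, though possibly within the scatter. The step expected is a 2.0-fold higher number from compound 3 to compound 4 (0.29 log units; within the scatter). Compound 4 is therefore estimated at 200 nM, between 70 nM and 600 nM.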

Compound 4, half-maximal effective concentration: 50 nM
Estimate against measurement, compound 4: 4.0-fold (0.60 log units) above, outside the stated range (below it).
By their numbers in this assay, from the lowest: compound 1; then compound 4; then compound 3; then compound 2.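

After a 2.0-fold lower number from compound 3 to compound 4 (0.31 log units; beyond the scatter) on replacing chloro and a 14-fold lower number from compound 2 to compound 4 (1.16 log units; beyond the scatter) on replacing cyano, fluoro gives the lowest number of the three groups on this aromatic carbon in this assay and the step from chloro is beyond the scatter. Yet a 6.8-fold higher number from compound 1 to compound 4 (0.84 log units; beyond the scatter) remains when 4-fluorophenyl stands in place of cyclohexyl, so none of these substituted aromatic rings matches the cyclohexyl of compound 1. Nothing given here accounts for this order. Going by these compounds, whether plain hydrogen, methoxy or trifluoromethyl on that carbon would extend the order remains open. So does whether a longer chain to the cyclohexyl would change the number.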